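The compounds below may be only part of what the source reports. "The series", "measured", "known", "first", "only" and "open" are said of these compounds alone.

Measured in a functional assay on HL-60 cells (Homo sapiens) for antiproliferative activity, read by MTT assay, with a stated time of 24 h; a higher number here means a weaker inhibitor, a lower number a stronger inhibitor:
- compound 1 `CCCCc1oc2ccccc2c1C(=O)c1cc(I)c(OCCCN2CCN(CC)CC2)c(I)c1`: 28500 nM
- compound 2 `CCCCc1oc2ccccc2c1C(=O)c1cc(I)c(OCCCN2CCN(Cc3ccccc3)CC2)c(I)c1`: > 50000 nM

For the measured compounds named here, compound 1 holds the only true number so far, 28500 nM. Compound 2 reads > 50000 nM, which is a limit of this assay and not a number.

The next compound to be read is compound 3 `CCCCc1oc2ccccc2c1C(=O)c1cc(I)c(OCCCNCc2ccccc2)c(I)c1`, which departs from compound 1 as follows: benzylamino in place of 4-ethylpiperazin-1-yl on a saturated chain carbon, three bonds along the chain from an oxygen on an aromatic ring. Benzylamino takes the place of 4-ethylpiperazin-1-yl on a saturated chain carbon, three bonds along the chain from an oxygen on an aromatic ring.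

Going by the values given here, only one measured step bears on this change: an at least 1.7-fold higher number from compound 1 to compound 2 (0.24 log units; that floor lies within the scatter). That step also brings in a phenyl, but it gives only a floor, and the floor lies within the scatter. Among the compounds with values here, it sets neither a size nor a firm direction for the change at hand, and the ring removed in compound 3 has no measured counterpart. No shift beyond the scatter is therefore expected in this assay.

The estimated step is a 1.0-fold lower number from compound 1 to compound 3 (0.01 log units; within the scatter). Compound 3 is expected at 28000 nM. The expected range for compound 3 runs from 11000 nM to 60000 nM.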

Compound 3, half-maximal inhibitory concentration: 4400 nM
Compound 3: middle estimate off by 6.4-fold (0.80 log units), on the high side; measured number below the stated range.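

In this assay, benzylamino in place of 4-ethylpiperazin-1-yl on a saturated chain carbon, three bonds along the chain from an oxygen on an aromatic ring, gives a 6.5-fold lower number from compound 1 to compound 3 (0.81 log units; beyond the scatter), so the group at this position can move the number beyond the scatter, which the floor from compound 2 could not show. The change keeps the count of 8 heavy atoms but replaces a six-membered non-aromatic ring with 2 hetero atoms by a six-membered aromatic ring of carbon only and brings in 1 hydrogen-bond donor, and this single step cannot separate these differences. Compound 2 also carries a phenyl, yet it reads only as a limit and not as a number: the limit of > 50000 nM in this assay, at which 1 of the 3 values shown sits.

Going by these compounds, it remains open whether the lower number follows the benzylamino group itself or the loss of the piperazine ring, a question that ethylamino or piperidin-1-yl on the same chain carbon would address. Also open, on these data alone, is whether a longer chain, such as 4-(benzylamino)butyl in place of 3-(benzylamino)propyl, would hold the number of compound 3.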